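This account rests on a few compounds, and the source may have more. Where it says the series, first, only, none or still open, it means among the compounds named here.

Working notes, series in an ADME assay on WEHI13 cells (Mus musculus) for cytotoxicity, read by MTT assay, with a stated time of 72 h; on this read-out higher numbers stand for lower toxicity in this test and lower numbers for higher toxicity in this test:
- compound 1 `CCN(CC)Cc1cc(-c2ccccc2)n(Nc2ccnc3cc(Cl)ccc23)c1C`: 4380 nM
- compound 2 `CCN(CC)Cc1cc(-c2ccc(Cl)cc2)n(Nc2ccnc3cc(Cl)ccc23)c1C`: 1450 nM
- compound 3 `Cc1c(CN2CCCC2)cc(-c2ccc(Cl)cc2)n1Nc1ccnc2cc(Cl)ccc12`: 2060 nM

Compound 3 at 2060 nM lies within the scatter of compound 2 at 1450 nM, and both numbers stand lower than that of compound 1 at 4380 nM.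

Next is compound 4 `Cc1c(CN2CCCC2)cc(-c2ccc(F)cc2)n1Nc1ccnc2cc(Cl)ccc12`, with fluoro in place of chloro on an aromatic carbon, para to a large group: fluoro in place of chloro on an aromatic carbon.

Within the data shown here, no fluoro compound has been measured, so any guide is indirect. Among the measured compounds shown here, the only measured step at this place is a 3.0-fold lower number from compound 1 to compound 2 (0.48 log units; beyond the scatter), with chloro in place of hydrogen. The other step, a 1.4-fold higher number from compound 2 to compound 3 (0.15 log units; within the scatter), concerns the amine and gives no guide here. Fluoro in place of chloro is expected to reverse a small part of the step to compound 2, at most, so only a slight rise is anticipated in this assay.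

The expected change is a 1.4-fold higher number from compound 3 to compound 4 (0.13 log units; within the scatter).

For compound 4 the estimated value is 2800 nM, with an expected range of 1300 nM to 6000 nM.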

Compound 4, half-maximal cytotoxic concentration: 2710 nM
Compound 4: the middle estimate sits 1.0-fold (0.01 log units) above what was measured, within the range that was stated.
By their numbers in this assay, from the lowest: compounds 2, 3, 4 and 1 (each within the scatter of the next, the first and the last beyond it).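

In this assay, the change from 4-chlorophenyl to 4-fluorophenyl on the pyrrolidin-1-yl background gives a 1.3-fold higher number from compound 3 to compound 4 (0.12 log units; within the scatter) and so leaves chloro and fluoro at this place not told apart in this read-out. Among these compounds, the only earlier step at this place, chloro in place of hydrogen on the diethylamino background, gave a 3.0-fold lower number from compound 1 to compound 2 (0.48 log units; beyond the scatter) and was beyond the scatter, so the present result adds that exchanging one halogen for the other at the same place produces no step beyond the scatter in this pair. Nothing at hand gives a cause for this result.

Open, from the compounds shown here alone, is whether a methoxy or trifluoromethyl group at this place would stand apart from chloro and fluoro. Also open, going by these compounds, is whether the same exchange of chloro for fluoro reads alike on the diethylamino background or with a morpholine as the amine.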